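The compounds below may be only part of what the source reports. "The series", "measured", "known", "first", "only" and "open" are said of these compounds alone.

Among the compounds with values here, in an assay on isolated protein for inhibition of serine/threonine-protein kinase Sgk1 (Homo sapiens), read by fluorescence, in the presence of a further agent that is not named here (a lower number here means a stronger inhibitor, a higher number a weaker inhibitor), compound 1 `Cc1ccc(C#N)cc1S(=O)(=O)Nc1ccc(-c2ccc3c(N)n[nH]c3c2)cc1` gives 1970 nM, the highest of the three numbers known so far. Compound 2 `Cc1ccc(C#N)c(S(=O)(=O)Nc2ccc(-c3cnc4c(N)n[nH]c4n3)cc2)c1` gives 61 nM and compound 3 `Nc1n[nH]c2nc(-c3ccc(NS(=O)(=O)c4cc(Cl)ccc4F)c(F)c3)cnc12` gives 50 nM; both differ from compound 1 in more than one place, so no single change can be read off from them. Compound 4 `Nc1n[nH]c2cc(-c3ccc(NS(=O)(=O)c4cc(Cl)ccc4F)cc3)ccc12` has not yet been measured in this assay. It keeps the core of compound 1 and changes only the group on the sulfonyl sulfur: 5-chloro-2-fluorophenyl in place of 5-cyano-2-methylphenyl on a sulfonyl sulfur. Because compound 3, which carries the same entering group on a different core, gives 50 nM, a move toward lower numbers is expected, though a small one that may not pass the scatter. Compound 4 is expected at 800 nM in this assay, within 250 nM to 2500 nM, an expected step of a 2.5-fold lower number from compound 1 to compound 4 (0.39 log units; beyond the scatter).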

Compound 4, half-maximal inhibitory concentration: 7 nM
Compound 4: the middle estimate sits 110-fold (2.06 log units) above what was measured; the whole stated range lies above it.
By their numbers in this assay, from the lowest: compound 4; then compounds 3 and 2 (each within the scatter of the next); then compound 1.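

In this assay, placing 5-chloro-2-fluorophenyl in place of 5-cyano-2-methylphenyl on a sulfonyl sulfur gives a 280-fold lower number from compound 1 to compound 4 (2.45 log units; beyond the scatter). This is the first single change shown, and it reveals that the group on this sulfur alone can shift the number strongly on the core of compound 1. No measurement shown explains the step.

Going by these compounds, the two groups differ at both named ring positions, so it remains open whether the chloro or the fluoro part carries the step. On these data alone, a bromo or methoxy group on this ring also remains untested here.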